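Azetidine to carboxypyrrolidine on the piperidine amine position

This account rests on a few compounds, and the source may have more. Where it says the series, first, only, none or still open, it means among the compounds named here.

Compound 1 `Cc1nn([C@H](C)c2ccc(Cl)cc2Cl)c2nc(N3CC[C@H](N4CCC4)[C@H](C)C3)cnc12` gives 58 nM in a functional assay on cells for antagonist activity at C-C chemokine receptor type 4 (Homo sapiens), read by fluorescence and calcium flux, with stated times of 2.5 s and 45 s (on this read-out lower numbers stand for stronger inhibition and higher numbers for weaker inhibition), and stands as the lowest of the two numbers at hand. Compound 2 `Cc1nn([C@H](C)c2ccc(Cl)cc2Cl)c2nc(N3CC[C@@H](N4CCCCC4)[C@@H](C)C3)cnc12` gives 803 nM in this assay; it differs from compound 1 in more than one place, so only the two values themselves can be compared. Compound 3 `Cc1nn([C@H](C)c2ccc(Cl)cc2Cl)c2nc(N3CC[C@H](N4CCC[C@H]4C(=O)O)[C@H](C)C3)cnc12` carries 2-carboxypyrrolidin-1-yl in place of azetidin-1-yl on a saturated ring carbon. Among the measured compounds shown here, no step of this kind has been measured in the set, so the size is uncertain; a move to a higher number, beyond the scatter, is expected. Compound 3 is expected to give 350 nM in this assay, within 70 nM to 1800 nM. The expected step from compound 1 to compound 3 is a 6.0-fold higher number from compound 1 to compound 3 (0.78 log units; beyond the scatter).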

Compound 3, half-maximal inhibitory concentration: 670 nM
The estimate for compound 3 lay 1.9-fold (0.28 log units) below the measured number; the measured number falls inside the stated range.
By their numbers in this assay, from the lowest: compound 1; then compounds 3 and 2 (each within the scatter of the next).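

In this assay, this saturated ring carbon now has its first one-place step: 2-carboxypyrrolidin-1-yl in place of azetidin-1-yl gives a 12-fold higher number from compound 1 to compound 3 (1.06 log units; beyond the scatter), so the group here clearly moves the read-out. The change alters ring size and adds a carboxylic acid and a defined stereocentre together, so the step cannot be divided among these features. Nothing available explains the step. Open, as far as these compounds go, is whether unsubstituted pyrrolidin-1-yl or the methyl ester of the acid would stay closer to compound 1, and whether the opposite configuration at the new stereocentre would change the number.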